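Methyl to Hydrogen on Two Related Cores

A few compounds are considered here, and "the series" means these few. Any claim that something is new, unique, unknown or untested is made for them only; others in the source may bear on it.

Measured in a functional assay on the whole organism for inhibition, with Mus musculus as the target, read by paw edema, with a stated time of 180 min, at a dose of 200 mg/kg by the oral route; a lower number here means a weaker effect, a higher number a stronger effect of the compound at the dose given:
compound 1, `CCn1c(Cn2c(=O)oc3ccc(C)cc32)n[nH]c1=S`: 31.8%
compound 2, `Cc1ccc2oc(=O)n(Cc3n[nH]c(=S)n3C)c2c1`: 38.6%
compound 3, `CCCNC(=S)NNC(=O)Cn1c(=O)oc2ccc(C)cc21`: 25.1%

Compound 2 differs from compound 1 by hydrogen in place of methyl on a saturated chain carbon bound to an aromatic nitrogen, and in this assay that gave a number 6.8 percentage points higher from compound 1 to compound 2 (within the scatter). Compound 3 gives a number within the scatter of compound 1 and beyond the scatter of compound 2; how the core of compound 3 differs from the core of compound 1 is not broken down here.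

Compound 4, `CCNC(=S)NNC(=O)Cn1c(=O)oc2ccc(C)cc21`, is not yet measured. It differs from compound 3 by hydrogen in place of methyl on a saturated chain carbon, two bonds along the chain from an amide-type nitrogen. This is the same kind of change as from compound 1 to compound 2, but the place is not the same: there the carbon was bound to an aromatic nitrogen, here it lies two bonds along the chain from an amide-type nitrogen. Because the earlier step was a number 6.8 percentage points higher from compound 1 to compound 2 (within the scatter), a step of similar size, a number 4.9 percentage points higher from compound 3 to compound 4 (within the scatter), is expected. Compound 4 is estimated to give 30%, between 18% and 42%.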

Compound 4, a percentage reported as inhibition, in the whole organism at one dose (the size of the read-out at that dose, not a potency): 54.6%
For compound 4 the middle estimate is 24.6 percentage points below the measured one; the measured number lies above the stated range.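

The step from propylamino to ethylamino gave a number 29.5 percentage points higher from compound 3 to compound 4 (beyond the scatter) in this assay, and the same change did not carry over at the same size from one core to the other: the same change on two cores in this assay, a number 6.8 percentage points higher (within the scatter) from compound 1 to compound 2 and a number 29.5 percentage points higher (beyond the scatter) from compound 3 to compound 4, 22.7 percentage points apart, beyond the scatter of two such steps. The change can therefore not be moved between these cores with its size assumed unchanged. This does not show what sets the two steps apart, since the carbon's place differs along with the core, and each step rests on a single pair at one dose.

The compounds shown leave open whether the rise continues with methylamino in place of ethylamino, or whether a longer chain such as butyl lowers the number further. They also leave open how a carboxylic acid or an amine at that place would read.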